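A few compounds are considered here, and "the series" means these few. Any claim that something is new, unique, unknown or untested is made for them only; others in the source may bear on it.

Measured so far:
compound 1 `O=c1oc2cccnc2n1CN1CCN(c2cccc(C(F)(F)F)c2)CC1` gives 25%
compound 2 `O=c1oc2cccnc2n1CN1CCN(c2cccc(Cl)c2)CC1` gives 27%

Both were tested in a functional assay on the whole organism for inhibition, with Rattus norvegicus as the target, read by paw edema, at a dose of 50 mg/kg; a higher number here means more inhibition at the dose given (going by the name of the read-out), a lower number less inhibition. In this assay, among the compounds with values here, compound 2 gives 27%, the higher of the two numbers, but its only neighbour, compound 1, gives 25%, and the step of a number 2 percentage points higher from compound 1 to compound 2 (within the scatter) lies within the scatter, so the two cannot be told apart.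

Compound 3 `O=c1oc2cccnc2n1CN1CCN(c2ccc(Cl)cc2)CC1` has not yet been measured. It differs from compound 2 by 4-chlorophenyl in place of 3-chlorophenyl on an amine nitrogen in a ring; the two share the same atoms, joined differently.

Within the data shown here, the only measured step, a number 2 percentage points higher from compound 1 to compound 2 (within the scatter), concerns a swap of one group for another on the same ring position and was within the scatter. Among the measured compounds shown here, no measured step shows what happens when the same atoms are joined differently, as here, so nothing in the numbers points in either direction. With so little to go on, the expectation is a step no larger than the scatter. Compound 3 is therefore estimated at 27%, with a range from 12% to 42%. This estimate corresponds to a step of no change at the digits printed from compound 2 to compound 3 (within the scatter), expected to stay within the scatter.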

Compound 3, a percentage reported as inhibition, in the whole organism at one dose (the size of the read-out at that dose, not a potency): 23%
For compound 3 the middle estimate is 4 percentage points above the measured one; low and high end bracket the measured number.
By their numbers in this assay, from the lowest: compounds 3, 1 and 2 (each within the scatter of the next).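

In this assay, with 4-chlorophenyl in place of 3-chlorophenyl on the amine nitrogen in the ring, the step is a number 4 percentage points lower from compound 2 to compound 3 (within the scatter), so compound 2 and compound 3 cannot be told apart. The entering and leaving groups have the same atoms and differ only in how those atoms are joined, so this pair tests the arrangement of the chlorophenyl group on its own, and at this single dose that arrangement produces no difference that can be read. No measurement at hand offers an explanation for this result.

The compounds shown leave open whether a different group on the phenyl ring, such as methoxy or an amine, or a plain phenyl without any added group, would give a reading that stands clear of these three. All three readings also come from a single dose, so it remains unsettled whether the compounds would separate at other doses or whether they would continue to read alike.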